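This account rests on a few compounds, and the source may have more. Where it says the series, first, only, none or still open, it means among the compounds named here.

Compound 1, `CC(C)(C)c1ccc(NC(=O)c2ccc(-c3ncccc3F)cc2)cc1`; in a functional assay for antagonist activity at transient receptor potential cation channel subfamily V member 1 (Homo sapiens), read by FLIPR (a higher number here means a weaker inhibitor, a lower number a stronger inhibitor), compound 1 gives 3 nM.
Compound 2, `CC(C)(C)c1ccc(NC(=O)c2ccc(-c3ncccc3NS(C)(=O)=O)cc2)cc1`; in this assay compound 2 gives 152 nM.

Compound 2 stands at the highest of the two numbers shown, and its only neighbour is compound 1, separated from it by a 51-fold higher number from compound 1 to compound 2 (1.70 log units; beyond the scatter). Compound 3, `CC(C)(C)c1ccc(NC(=O)c2ccc(-c3ncccc3C(=N)N)cc2)cc1`, has not yet been measured. It differs from compound 2 by a group of 3 heavy atoms (1 carbon, 2 nitrogen; no ring) in place of a group of 5 heavy atoms (1 carbon, 1 nitrogen, 2 oxygen, 1 sulfur; no ring), on an aromatic carbon. Among the measured compounds shown here, the one measured step that bears on this position is a 51-fold higher number from compound 1 to compound 2 (1.70 log units; beyond the scatter), which was large. For the measured compounds named here, no measured step shows the entering group anywhere, so its effect is open. For compound 3 the expected value is 300 nM, ranging from 50 nM to 3000 nM. This estimate means a step of a 2.0-fold higher number from compound 2 to compound 3 (0.30 log units; within the scatter) is expected.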

Compound 3, half-maximal inhibitory concentration: > 4000 nM
Compound 3 was reported as a limit (the forecaster's own chance of this, stated with the estimate: 10%); middle value at least 13-fold (1.12 log units) away from the limit.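

In this assay compound 3 is reported only as a limit, not as a number: the limit of > 4000 nM in this assay, at which 1 of the 3 values shown sits. Even so, the steps can be read as lower bounds: putting the group of 3 heavy atoms in place of methanesulfonamido gives an at least 26-fold higher number from compound 2 to compound 3 (1.42 log units; beyond the scatter), and putting it in place of fluoro gives an at least 1300-fold higher number from compound 1 to compound 3 (3.12 log units; beyond the scatter). The earlier pair showed one large rise on leaving fluoro; this result adds that a group with fewer heavy atoms than methanesulfonamido raises the number further, so heavy-atom count alone does not order the three compounds at this position.

From the compounds shown here alone, how far compound 3 lies past its limit stays open. So does whether a plain amine or a nitrile on this aromatic carbon would come closer to compound 1.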